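A few compounds are considered here, and "the series" means these few. Any claim that something is new, unique, unknown or untested is made for them only; others in the source may bear on it.

Compound 1 `COc1ncnc2c1c(-c1ccoc1)cn2[C@@H]1O[C@H](CO)[C@@H](O)[C@H]1O` carries a furan-3-yl group on its core. In a functional assay on A549 cells (Homo sapiens), read by MTT assay, with a stated time of 72 h (a lower number here means a stronger inhibitor, a higher number a weaker inhibitor), compound 1 gives 1160 nM. Compound 2 `COc1ncnc2c1c(-c1ccccc1)cn2[C@@H]1O[C@H](CO)[C@@H](O)[C@H]1O` differs by phenyl in place of furan-3-yl on an aromatic carbon. In this assay compound 2 reaches only a limit of the assay, > 20000 nM. The step is an at least 17-fold higher number from compound 1 to compound 2 (1.23 log units; beyond the scatter); it is the only measured step and it ends at the limit of > 20000 nM in this assay, at which 1 of the 2 values shown sits, so compound 2 stands at the weak end of the two numbers shown, its exact value unknown.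

Compound 3 `COc1ncnc2c1c(I)cn2[C@@H]1O[C@H](CO)[C@@H](O)[C@H]1O` is the next step: iodo in place of phenyl on an aromatic carbon. For the measured compounds named here, no measured step covers an iodo group, so the only guide is that phenyl gave the weaker result of the pair in this assay, while the furan-3-yl of compound 1 gave a number. Iodo is a far smaller group than phenyl by the atoms counted, so compound 3 is expected to return into the measurable range, though the size of a step starting from a limit cannot be fixed. Compound 3 is estimated at 6000 nM in this assay, between 1000 nM and 20000 nM. The expected step is an at least 3.3-fold lower number from compound 2 to compound 3 (0.52 log units; beyond the scatter).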

Compound 3, half-maximal inhibitory concentration: > 20000 nM
Compound 3: no number, only a limit; the forecaster's own chance of this, stated with the estimate: 35%; middle value at least 3.3-fold (0.52 log units) from the limit.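

With iodo on the aromatic carbon of the five-membered ring, compound 3 also reaches only a limit of the assay in this assay, > 20000 nM. Iodo in place of furan-3-yl gives an at least 17-fold higher number from compound 1 to compound 3 (1.23 log units; beyond the scatter), so a single iodine atom ends at the same limit as the six carbons of phenyl, and among the three groups shown only furan-3-yl yields a number. The step between compound 2 and compound 3 cannot be read, and the phenyl and iodo groups cannot be ranked against each other: the limit of > 20000 nM in this assay, at which 2 of the 3 values shown sit.

The compounds shown leave open whether the measurable value of compound 1 is tied to furan-3-yl itself or would also appear with a related ring such as thiophen-3-yl or furan-2-yl. They also leave open whether a group without a ring, such as an amine, a carboxylic acid or a short ethyl chain, would give a number at this position in this assay.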